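Swapping a cyclopentyl amide for a chlorobenzylidene hydrazide

The compounds below may be only part of what the source reports. "The series", "measured", "known", "first", "only" and "open" are said of these compounds alone.

The measured compounds and their values:
Compound 1 `Nc1c(C(=O)N/N=C/c2ccc(Br)cc2)oc2nc(-c3cccs3)cc(C(F)(F)F)c12`: in an ADME assay on HEK293 cells (Homo sapiens) for antiproliferative activity, read by MTT assay (a lower number here means a stronger inhibitor, a higher number a weaker inhibitor), compound 1 gives 86000 nM.
Compound 2 `Nc1c(C(=O)NC2CCCC2)oc2nc(-c3ccccc3)cc(C(F)(F)F)c12`: in this assay compound 2 gives 85000 nM.
Compound 3 `Nc1c(C(=O)N/N=C/c2ccccc2)oc2nc(-c3cccs3)cc(C(F)(F)F)c12`: in this assay compound 3 gives 72000 nM.

Compound 2 stands second highest of these three numbers, with compound 1 nearest and compound 3 furthest, both within the scatter of it. Among the compounds with values here, the only step between two measured compounds that differ in a single place is a 1.2-fold lower number from compound 1 to compound 3 (0.08 log units; within the scatter), which is within the scatter.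

Compound 4 `Nc1c(C(=O)N/N=C/c2ccc(Cl)cc2)oc2nc(-c3ccccc3)cc(C(F)(F)F)c12` differs from compound 2 by a group of 9 heavy atoms (7 carbon, 1 nitrogen, 1 chlorine; one six-membered aromatic ring of carbon only) in place of a group of 5 heavy atoms (5 carbon; one five-membered non-aromatic ring of carbon only), on an amide-type nitrogen. Within the data shown here, no measured step covers this exact change. Compounds 1 and 3 carry a hydrazide-type group of this kind, yet they sit on a different core than compound 2 and compound 4, so they bear on the step only loosely. All three measured values lie within the scatter of one another, whatever the group on the amide-type nitrogen, so no step beyond the scatter is expected here.

Compound 4 is therefore estimated at 80000 nM, with a range from 40000 nM to 160000 nM, an expected step of a 1.1-fold lower number from compound 2 to compound 4 (0.03 log units; within the scatter).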

Compound 4, half-maximal inhibitory concentration: 81000 nM
Beside the measured number, compound 4's estimate is 1.0-fold (0.01 log units) below it; the range from low to high includes it.
By their numbers in this assay, from the lowest: compounds 3, 4, 2 and 1 (each within the scatter of the next).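

On the amide-type nitrogen, the comparison in this assay gives a 1.0-fold lower number from compound 2 to compound 4 (0.02 log units; within the scatter) and so shows no readable difference when the cyclopentyl group gives way to the larger group that carries an aromatic ring and a chlorine. Compound 1 and compound 3 could not show this, as they carry a hydrazide-type group on a different core, whereas this pair isolates the change at this one place on the core of compound 2. No measurement here explains why the two groups give values within the scatter of each other.

Still open, on these data alone, is whether a different group on this nitrogen, such as a carboxylic acid or a chain ending in an amine, would give a step beyond the scatter. Also open, as far as these compounds go, is what hydrogen in place of the chlorine would do on the core of compound 2.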